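A few compounds are considered here, and "the series" means these few. Any claim that something is new, unique, unknown or untested is made for them only; others in the source may bear on it.

Three compounds have numbers in a functional assay on Huh-7 cells (Homo sapiens) for cytotoxicity, read by resazurin assay, with a stated time of 48 h; on this read-out lower numbers stand for stronger inhibition and higher numbers for weaker inhibition:

compound 1, `C=CCNc1[nH]nc(N)c1C(=O)Nc1ccc(OCC)cc1`, gives 22000 nM
compound 2, `CCNc1[nH]nc2nnn(-c3ccc(OCC)cc3)c(=O)c12`, gives 14400 nM
compound 3, `CCN/C(SC)=C(/C#N)C(=O)Nc1ccc(OCC)cc1`, gives 16400 nM

Compound 1 carries the highest of the three numbers in this assay. The nearest to it is compound 3 and the furthest is compound 2, yet both gaps fall within the usual scatter of repeated measurements, so the three compounds cannot be ordered against each other on these numbers alone.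

Compound 4, `CCOc1ccc(NC(=O)c2c(N)n[nH]c2NC)cc1`, keeps the core of compound 1 and differs from it in one place: hydrogen in place of vinyl on a saturated chain carbon bound to a nitrogen on an aromatic ring. Going by the values given here, no measured pair in this set differs at that place, so there is no measured step to lean on for the size of the change. A small edit of this kind at an allylamino group, with nothing else touched, is expected to move the number little; the step from compound 1 to compound 4 is estimated as no change at the digits printed from compound 1 to compound 4 (within the scatter), that is, none beyond the scatter. Compound 4 is therefore expected to give 22000 nM in this assay, with a range from 9000 nM to 55000 nM.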

Compound 4, half-maximal inhibitory concentration: 21800 nM
Compound 4: the middle estimate sits 1.0-fold (0.00 log units) above what was measured; the range from low to high includes it.
By their numbers in this assay, from the lowest: compounds 2, 3, 4 and 1 (each within the scatter of the next).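

Going from allylamino to methylamino on the shared core gives a 1.0-fold lower number from compound 1 to compound 4 (0.00 log units; within the scatter) in this assay and provides the first measured step at this place. Removing the vinyl, with its two carbons and its double bond outside aromatic rings, leaves the number within the scatter, so for this pair the shortening of the chain makes no measurable difference to the read-out. Nothing available explains why the number stays put at this place.

Going by these compounds alone, with only this one pair differing here, it remains open whether a longer chain, a benzyl group or a chain ending in a carboxylic acid would leave the number equally unmoved. As far as these compounds go, it is also open whether any group at this place can carry the number beyond the scatter at all.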